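This account rests on a few compounds, and the source may have more. Where it says the series, first, only, none or still open, it means among the compounds named here.

Compound 1 `CNC(=O)CCCCCCCn1nc(-c2cnc3[nH]ccc3c2)c2c(N)ncnc21` gives 5630 nM
Compound 2 `Nc1ncnc2c1c(-c1cnc3[nH]ccc3c1)nn2CCCCCCCCC(=O)NO` gives 3050 nM

Both were measured in a functional assay on HepG2 cells (Homo sapiens) for inhibition, read by MTT assay, with a stated time of 72 h (a higher number here means a weaker inhibitor, a lower number a stronger inhibitor), and compound 2 stands level with compound 1, within the scatter. Compound 3 `Nc1ncnc2c1c(-c1cnc3[nH]ccc3c1)nn2CCCCC(=O)NO` carries hydroxycarbamoyl in place of 4-(hydroxycarbamoyl)butyl on a saturated chain carbon, four bonds along the chain from an aromatic nitrogen. Among the measured compounds shown here, the one measured step that bears on this (a 1.8-fold lower number from compound 1 to compound 2 (0.27 log units; within the scatter)) altered the chain end and not the chain length, so no measurement covers a shortened chain. With so little to go on, no change beyond the scatter is expected in this assay and the expected step is small (a 1.1-fold higher number from compound 2 to compound 3 (0.06 log units; within the scatter)). Compound 3 is estimated at 3500 nM (expected range 1000 nM to 12000 nM).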

Compound 3, half-maximal inhibitory concentration: 36700 nM
Compound 3: middle estimate off by 10-fold (1.02 log units), on the low side, outside the stated range (above it).
By their numbers in this assay, from the lowest: compounds 2 and 1 (each within the scatter of the next); then compound 3.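

In this assay, chain length at this position counts for far more than the chain end, which was all the earlier pair varied: hydroxycarbamoyl in place of 4-(hydroxycarbamoyl)butyl gives a 12-fold higher number from compound 2 to compound 3 (1.08 log units; beyond the scatter). Hydroxycarbamoyl in place of 3-(methylcarbamoyl)propyl gives a 6.5-fold higher number from compound 1 to compound 3 (0.81 log units; beyond the scatter), so the shortened chain is weaker than both longer chains. Nothing available explains this loss.

Still open, going by these compounds, is how a chain of intermediate length would behave. Also open, on these data alone, is whether a carboxylic acid or an amine at the chain end would give similar numbers.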